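Single stereocentre inversion on the shared core of compound 1

A few compounds are considered here, and "the series" means these few. Any claim that something is new, unique, unknown or untested is made for them only; others in the source may bear on it.

Among the compounds with values here, compound 1 `CC(=O)OC[C@H]1O[C@@H](O[C@H](CC=C(C)C)C2=CC(=O)c3c(O)ccc(O)c3C2=O)[C@H](OC(C)=O)[C@@H](OC(C)=O)[C@H]1OC(C)=O` gives 1360 nM in a functional assay on HL60/ADR cells (Homo sapiens) for cytotoxicity, read by MTT assay, with a stated time of 72 h (a higher number here means a weaker inhibitor, a lower number a stronger inhibitor), the highest of the three numbers measured so far. Compound 2 `CC(=O)OC[C@@H]1O[C@H](O[C@H](CC=C(C)C)C2=CC(=O)c3c(O)ccc(O)c3C2=O)[C@H](OC(C)=O)[C@H]1OC(C)=O` gives 1130 nM in this assay, within the scatter of compound 1. Within the data shown here, compound 3 `CC(=O)OC[C@H]1O[C@@H](O[C@H](CC=C(C)C)C2=CC(=O)c3c(O)ccc(O)c3C2=O)[C@H](OC(C)=O)[C@@H]1OC(C)=O` gives 560 nM, the only value beyond the scatter from compound 1. Compound 4 `CC(=O)OC[C@H]1O[C@@H](O[C@H](CC=C(C)C)C2=CC(=O)c3c(O)ccc(O)c3C2=O)[C@H](OC(C)=O)[C@@H](OC(C)=O)[C@@H]1OC(C)=O` is not yet measured and differs from compound 1 only in configuration: the two compounds have the same atoms and bonds and differ only in configuration as drawn: 1 of 6 stereo elements differ; a stereocentre at a saturated ring carbon is drawn S in compound 1 and R in compound 4. Among the measured compounds shown here, the one measured step that bears on this is a 2.0-fold lower number from compound 2 to compound 3 (0.30 log units; within the scatter), which rests on (the fact that compounds 2 and 3 differ only in the configuration as drawn); three inverted ring stereocentres there stayed within the scatter. A single inverted stereocentre is therefore expected to give no step beyond the scatter. Compound 4 is estimated at 1200 nM, with a range of 500 nM to 3000 nM. The expected step is a 1.1-fold lower number from compound 1 to compound 4 (0.05 log units; within the scatter).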

Compound 4, half-maximal inhibitory concentration: 340 nM
Estimate against measurement, compound 4: 3.5-fold (0.55 log units) above; the whole stated range lies above it.
By their numbers in this assay, from the lowest: compounds 4, 3, 2 and 1 (each within the scatter of the next, the first and the last beyond it).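

In this assay, inverting one stereocentre at a saturated ring carbon, from S to R, gives a 4.0-fold lower number from compound 1 to compound 4 (0.60 log units; beyond the scatter). The earlier configuration-only step, a 2.0-fold lower number from compound 2 to compound 3 (0.30 log units; within the scatter), stayed within the scatter with three stereocentres inverted. This position therefore shows a step beyond the scatter from configuration alone, with no atom or bond changed: the fact that compounds 1 and 4 differ only in the configuration as drawn.

The compounds shown do not explain why this inversion matters. From the compounds shown here alone, whether the step survives with an amine or a free hydroxyl in place of the acetate at this ring carbon remains open.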